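Ethylamino for Chloro on the Shared Core

This account rests on a few compounds, and the source may have more. Where it says the series, first, only, none or still open, it means among the compounds named here.

Measured compounds:
compound 1, `COc1cc(C2C(C#N)=C(N)Oc3cc(Cl)ccc32)cc(Br)c1OC`, gives 160000000 nM in a functional assay on T47D cells (Homo sapiens) for activation; a lower number here means that less compound is needed, a higher number that more compound is needed for the effect;
compound 2, `CCNc1ccc2c(c1)OC(N)=C(C#N)C2c1cc(OC)cc(OC)c1`, gives 61700000 nM in this assay.

Compound 1 stands at the highest of the two numbers in this assay; compound 2, its nearest neighbour, sits at a lower number, and the gap between compound 1 and compound 2 lies beyond the usual scatter. Among the measured compounds shown here, the two compounds differ in more than one place, so no single step between them is counted; their values simply show that the ethylamino-bearing compound 2 needs less compound than the chloro-bearing compound 1.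

Compound 3, `CCNc1ccc2c(c1)OC(N)=C(C#N)C2c1cc(Br)c(OC)c(OC)c1`, has not yet been measured in this assay. It arises from compound 1 by the change (ethylamino in place of chloro on an aromatic carbon). For the measured compounds named here, the same group that enters here is the one carried by compound 2, whose value 61700000 nM sits below that of compound 1. On that basis a modest step towards a lower number is expected for compound 3, roughly a 2.3-fold lower number from compound 1 to compound 3 (0.36 log units; beyond the scatter), though the values at hand are few. Compound 3 is therefore estimated at 70000000 nM, with a range from 25000000 nM to 200000000 nM.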

Compound 3, half-maximal effective concentration: 14000000 nM
Compound 3: the middle estimate sits 5.0-fold (0.70 log units) above what was measured; the whole stated range lies above it.
By their numbers in this assay, from the lowest: compound 3; then compound 2; then compound 1.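

In this assay, among the compounds shown here, the exchange on this aromatic carbon, meta to a fused ring and para to a fused ring, gives an 11-fold lower number from compound 1 to compound 3 (1.06 log units; beyond the scatter), the first single change that can be read here, as compound 1 and compound 2 differ in more than one place. It shows that the number in this assay responds strongly to what this position carries: with the rest of compound 1 held fixed, ethylamino, with its three heavy atoms and the hydrogen-bond donor and acceptor that chloro does not have, brings a large move to a lower number. No measurement at hand bears on why the step is this large, so these counted differences describe the change and do not account for it.

The compounds shown leave open whether this step belongs to ethylamino in particular, or whether a plain amine, methylamino, a longer chain such as propylamino, or an ether such as methoxy on the same carbon would give a similar step. They also leave open whether the same exchange would give a step of like size in a compound lacking the bromo group.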